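Trimming a tert-Butoxycarbonyl Group to Methoxycarbonyl

The source may report more compounds than this note shows. Statements on the series, on what has been measured and on what is new or still open speak of the compounds shown alone.

Of the compounds shown here, three sharing one core have been tested in an ADME assay on microsomes from liver (Rattus norvegicus) for metabolic stability, with a stated time of 10 min; a higher number here means that more of the compound is left, a lower number that less of the compound is left. Compound 1 `CC(C)NCCS(=O)(=O)NC(=O)c1ccc(Nc2nc(NC3(c4ccc(Cl)cc4)CC3)nc(OCC(F)(F)F)n2)cc1` gives 100%. Compound 2 `CC(C)(C)OC(=O)NCCS(=O)(=O)NC(=O)c1ccc(Nc2nc(NC3(c4ccc(Cl)cc4)CC3)nc(OCC(F)(F)F)n2)cc1` gives 93%, and compound 3 `O=C(NS(=O)(=O)C1CC1)c1ccc(Nc2nc(NC3(c4ccc(Cl)cc4)CC3)nc(OCC(F)(F)F)n2)cc1` gives 85%. The step of a number 7 percentage points lower from compound 1 to compound 2 (within the scatter) and the step of a number 8 percentage points lower from compound 2 to compound 3 (within the scatter) both stay within the scatter, so the three numbers cannot be told apart in this assay. Compound 4 `COC(=O)NCCS(=O)(=O)NC(=O)c1ccc(Nc2nc(NC3(c4ccc(Cl)cc4)CC3)nc(OCC(F)(F)F)n2)cc1` arises from compound 2 by methyl in place of tert-butyl on an oxygen next to a carbonyl group. Among the compounds with values here, no measured step touches this part of the molecule, so nothing directly predicts the outcome; the two steps around compound 2 were small. The expectation is therefore a step from compound 2 to compound 4 of no size beyond the scatter, a number 3 percentage points lower from compound 2 to compound 4 (within the scatter). Compound 4 is estimated at 90%, with a range from 75% to 100%.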

Compound 4, percent of the compound remaining: 100%
For compound 4 the middle estimate is 10 percentage points below the measured one; the measured number falls inside the stated range.
By their numbers in this assay, from the lowest: compounds 3, 2, 1 and 4 (each within the scatter of the next, the first and the last beyond it).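

Replacing tert-butyl with methyl on an oxygen next to a carbonyl group gives a number 7 percentage points higher from compound 2 to compound 4 (within the scatter) in this assay, so this change at this position shows no measurable effect here. Likewise, methoxycarbonyl in place of isopropyl on an amine nitrogen gives no change at the digits printed from compound 1 to compound 4 (within the scatter). The full 2-((methoxycarbonyl)amino)ethyl group in place of cyclopropyl on a sulfonyl sulfur gives a number 15 percentage points higher from compound 3 to compound 4 (beyond the scatter), a modest step beyond the scatter.

No supporting measurement explains these numbers. As far as these compounds go, the result for a carboxylic acid or a longer chain in place of methoxycarbonyl remains open.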